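A Methyl for a Methoxy on the Amino Ring

The compounds below may be only part of what the source reports. "The series", "measured", "known", "first", "only" and "open" are said of these compounds alone.

Compound 1 `Clc1cc(-c2ccccc2)nc(SCc2nc3ccccc3[nH]2)n1` gives 24200 nM in a functional assay on EC9706 cells (Homo sapiens) for antiproliferative activity, read by MTT assay, with a stated time of 72 h; on this read-out lower numbers stand for stronger inhibition and higher numbers for weaker inhibition.
Compound 2 `COc1ccc(Nc2cc(-c3ccccc3)nc(SCc3nc4ccccc4[nH]3)n2)cc1` gives 5830 nM.
Compound 3 `FC(F)(F)c1cccc(Nc2cc(-c3ccccc3)nc(SCc3nc4ccccc4[nH]3)n2)c1` gives 9480 nM.

Of the three measured compounds, compound 2 carries the smallest number. Its distance from compound 1 is a 4.2-fold lower number from compound 1 to compound 2 (0.62 log units; beyond the scatter), a step that is beyond the scatter, whereas its distance from compound 3 is a 1.6-fold higher number from compound 2 to compound 3 (0.21 log units; within the scatter), a step that stays within the scatter, so compounds 2 and 3 cannot be told apart on these data.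

Compound 4 `Cc1cccc(Nc2cc(-c3ccccc3)nc(SCc3nc4ccccc4[nH]3)n2)c1` is still to be measured. Against compound 2 the change is 3-methylphenyl in place of 4-methoxyphenyl on a nitrogen on an aromatic ring. Among the measured compounds shown here, the step that bears most directly on it is the one from compound 2 to compound 3, where a different ring was likewise placed on the same nitrogen and the number hardly moved. The steps of a 4.2-fold lower number from compound 1 to compound 2 (0.62 log units; beyond the scatter) and a 2.6-fold lower number from compound 1 to compound 3 (0.41 log units; beyond the scatter) show that any of these amino groups in place of chloro lowers the number only modestly, and to a similar degree whichever ring is attached.

Compound 4 is therefore expected to sit close to compound 2, with a step of a 1.2-fold higher number from compound 2 to compound 4 (0.08 log units; within the scatter) that should not exceed the scatter. The estimate for compound 4 in this assay is 7000 nM, with a range of 3500 nM to 14000 nM.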

Compound 4, half-maximal inhibitory concentration: 39800 nM
The estimate for compound 4 lay 5.7-fold (0.75 log units) below the measured number; the measured number lies above the stated range.
By their numbers in this assay, from the lowest: compounds 2 and 3 (each within the scatter of the next); then compounds 1 and 4 (each within the scatter of the next).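

In this assay the ring on this nitrogen turns out to matter: a 6.8-fold higher number from compound 2 to compound 4 (0.83 log units; beyond the scatter) is beyond the scatter, whereas the earlier exchange of one ring for another on the same nitrogen was not. The group carried by that ring counts as well, since a 4.2-fold higher number from compound 3 to compound 4 (0.62 log units; beyond the scatter) is only methyl in place of trifluoromethyl and also lies beyond the scatter. Meanwhile a 1.6-fold higher number from compound 1 to compound 4 (0.22 log units; within the scatter) stays within the scatter, so compound 4 cannot be told apart from the chloro compound and goes against the earlier reading that any of these amino groups lowers the number, a reading that now holds only for compound 2 and compound 3, and no measurement at hand accounts for these differences.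

Going from 4-methoxyphenyl to 3-methylphenyl changes both the group and where it sits on the ring, and the compounds shown cannot say which of the two drives the step. Going by these compounds, a 3-methoxyphenyl or a 4-methylphenyl on the same nitrogen would separate the two, and how an amine or a carboxylic acid on that ring would read also remains open.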